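Dropping the Methyl from Compound 3: An Expected Null Result

The source may hold more compounds than are shown below. What is called first, only, known or untested is meant among the compounds shown, and "the series" means these compounds.

Compound 1 `C[C@H]1N=C2C[C@H]3C[C@H](C3(C)C)[C@@]2(C)OC1=O` — > 1800000 nM
Compound 2 `CC(C)(C)OC(=O)NCCC[C@H]1N=C2C[C@H]3C[C@H](C3(C)C)[C@@]2(C)OC1=O` — > 1500000 nM
Compound 3 `C[C@@H]1N=C2C[C@@H]3C[C@@H](C3(C)C)[C@]2(C)OC1=O` — > 2000000 nM

In an ADME assay on NIH3T3 cells (Mus musculus) for antiproliferative activity, read by sulforhodamine B assay, with a stated time of 48 h (on this read-out higher numbers stand for weaker inhibition and lower numbers for stronger inhibition), compound 1 gives > 1800000 nM, which is a limit of the assay rather than a number. Compound 2 gives > 1500000 nM, again a limit. Compound 3 gives > 2000000 nM, also a limit. Compound 3 thus stands among three values that are all limits, and none of the three shows measurable inhibition. Among the measured compounds shown here, the only step between measured compounds that differ in one place is a step that the two limits leave unreadable from compound 1 to compound 3; because of the fact that compounds 1 and 3 differ only in the configuration as drawn together with the limit of > 1800000 nM in this assay, at which 1 of the 3 values shown sits, and the limit of > 2000000 nM in this assay, at which 1 of the 3 values shown sits, its size cannot be read.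

Compound 4 `CC1(C)[C@@H]2CC3=NCC(=O)O[C@@]3(C)[C@H]1C2` differs from compound 3 by hydrogen in place of methyl on a saturated ring carbon. For the measured compounds named here, no measured step bears directly on this change, and the single step that exists, from compound 1 to compound 3, is itself unreadable. Given that compound 3 sits at > 2000000 nM, the expected step of a number no higher from compound 3 to compound 4 (the limit leaves the size open) is none beyond the scatter. Compound 4 is therefore estimated at 2000000 nM, with a range from 500000 nM to 6000000 nM, most probably reported again only as a limit.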

Compound 4, half-maximal inhibitory concentration: > 900000 nM
Compound 4: no number, only a limit (the forecaster's own chance of this, stated with the estimate: 90%); the middle value lies beyond the limit too.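

Compound 4 gives > 900000 nM, which is a limit of the assay and not a number. Compound 3 also has only a limit, so no step can be read between compound 3 and compound 4. The compounds shown leave open whether hydrogen in place of methyl changes inhibition at all, and whether any of the four compounds inhibits measurably.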